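The source may hold more compounds than are shown below. What is called first, only, known or untested is meant among the compounds shown, and "the series" means these compounds.

Working notes on the series.

For the measured compounds named here, the shared core carries a 4-hydroxyphenyl group and an ether chain; the three measured members differ only in that chain. In an assay (Cricetulus griseus) for inhibition of Monoamine oxidase (Homo sapiens) (a lower number here means a stronger inhibitor, a higher number a weaker inhibitor), compound 1, `CCOC(=O)CCCCOc1ccc2c(=O)c(-c3ccc(O)cc3)coc2c1`, returns > 9000 nM, which is a limit of the assay rather than a number. Compound 2, `NCCCCOc1ccc2c(=O)c(-c3ccc(O)cc3)coc2c1`, likewise returns > 9000 nM in this assay, again a limit. Compound 3, `CCCCC(Oc1ccc2c(=O)c(-c3ccc(O)cc3)coc2c1)C(=O)OCC`, returns >> 9000 nM in this assay, also a limit. Going by the values given here, the one step that can be formed, a step that the two limits leave unreadable from compound 1 to compound 2, is unreadable because both ends sit at a limit; see (the limit of > 9000 nM in this assay, at which 2 of the 3 values shown sit). The third member sits at the limit described in the limit of >> 9000 nM in this assay, at which 1 of the 3 values shown sits.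

Compound 4, `O=C(O)COc1ccc2c(=O)c(-c3ccc(O)cc3)coc2c1`, differs from compound 1 by carboxy in place of 3-(ethoxycarbonyl)propyl on a saturated chain carbon bound to an oxygen on an aromatic ring. Among the compounds with values here, no measured step bears on this change, and no step has a readable size: every value shown is a limit. The expectation for compound 4 is therefore that it stays at the same limit, meaning a step that the limit leaves unreadable from compound 1 to compound 4 from compound 1, which is not beyond the scatter in any readable sense. The estimate for compound 4 in this assay is 20000 nM, with a range from 6000 nM to 100000 nM, and most likely reported only as a limit.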

Compound 4, half-maximal inhibitory concentration: >> 9000 nM
Compound 4: only a limit was reported; the forecaster's own chance of this, stated with the estimate: 80%; the middle value lies beyond the limit too.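

In this assay compound 4 gives >> 9000 nM and this is a limit of the assay, not a number. No new step can be read from compound 1 or compound 2 to compound 4, as the values sit at limits: the limit of >> 9000 nM in this assay, at which 2 of the 4 values shown sit.

The compounds shown leave open whether any ether chain on the shared core gives a readable value in this assay at all.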